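The compounds below may be only part of what the source reports. "The series", "measured", "known", "first", "only" and "open" are said of these compounds alone.

Compound 1, `COc1cc2ncnc(N3CCc4ccccc43)c2cc1NC(=O)/C=C/C(C)C`, gives 6530 nM in a functional assay on PC-3 cells (Homo sapiens) for antiproliferative activity, read by MTT assay, with a stated time of 72 h; a higher number here means a weaker inhibitor, a lower number a stronger inhibitor.
Compound 2, `CC(C)/C=C/C(=O)Nc1cc2c(N3CCc4ccccc43)ncnc2cc1O[C@@H]1CCOC1`, gives 11200 nM in this assay.
Compound 3, `COc1cc2ncnc(N3CCc4ccccc43)c2cc1NC(=O)/C=C/CN(C)C`, gives 2190 nM in this assay.

Compound 1 and compound 2 differ by oxolan-3-yl in place of methyl on an oxygen on an aromatic ring, a change that gave a 1.7-fold higher number from compound 1 to compound 2 (0.23 log units; within the scatter). Compound 3 carries a different core from compound 1, the difference being ((dimethylamino)methyl in place of isopropyl on a double-bonded chain carbon bound to a double-bonded chain carbon), and this step gave a 3.0-fold lower number from compound 1 to compound 3 (0.47 log units; beyond the scatter), the lowest number of the three.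

Compound 4, `CN(C)C/C=C/C(=O)Nc1cc2c(N3CCc4ccccc43)ncnc2cc1O[C@@H]1CCOC1`, is not yet measured. It differs from compound 3 by oxolan-3-yl in place of methyl on an oxygen on an aromatic ring, at a place described in the same words as for the change from compound 1 to compound 2, so it is the same change on the core of compound 3. Its step is expected to be similar in size, a 1.7-fold higher number from compound 3 to compound 4 (0.23 log units; within the scatter), resting on a 1.7-fold higher number from compound 1 to compound 2 (0.23 log units; within the scatter). Compound 4 is therefore estimated at 3700 nM in this assay, between 1500 nM and 9000 nM.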

Compound 4, half-maximal inhibitory concentration: 1230 nM
Compound 4: the middle estimate sits 3.0-fold (0.48 log units) above what was measured, outside the stated range (below it).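

In this assay, the swap of oxolan-3-yl for methyl gives a 1.8-fold lower number from compound 3 to compound 4 (0.25 log units; within the scatter), and although each step on its own lies within the scatter, the two cores do not agree: the same change on two cores in this assay, a 1.7-fold higher number (0.23 log units; within the scatter) from compound 1 to compound 2 and a 1.8-fold lower number (0.25 log units; within the scatter) from compound 3 to compound 4, 3.1-fold (0.48 log units) apart, beyond the scatter of two such steps
The swap of (dimethylamino)methyl for isopropyl gives a lower number on both cores, with a 9.1-fold lower number from compound 2 to compound 4 (0.96 log units; beyond the scatter), but the size does not carry over: the same change on two cores in this assay, a 3.0-fold lower number (0.47 log units; beyond the scatter) from compound 1 to compound 3 and a 9.1-fold lower number (0.96 log units; beyond the scatter) from compound 2 to compound 4, 3.1-fold (0.48 log units) apart, beyond the scatter of two such steps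
Both gaps come from the same four compounds, so they are a single observation that the two changes do not add up, and they show neither its cause nor how other cores would behave.

Still open, as far as these compounds go, is whether a piperidine or morpholine in place of the dimethylamino group would show the same dependence on the group on the oxygen. Also open, from the compounds shown here alone, is whether a longer chain on that oxygen would do so.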